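From Aryl to Cycloalkyl on the Amine Nitrogen

The compounds below may be only part of what the source reports. "The series", "measured", "known", "first", "only" and "open" are said of these compounds alone.

In a functional assay on HeLa cells (Homo sapiens) for inhibition, read by sulforhodamine B assay (on this read-out higher numbers stand for weaker inhibition and lower numbers for stronger inhibition), compound 1 `COc1ccccc1NC1=CC(=O)c2c(nc3n2[C@H]2OC[C@@H](O)[C@H]2OC3)C1=O` gives 7460 nM. Compound 3 `COc1ccc(NC2=CC(=O)c3nc4n(c3C2=O)[C@H]2OC[C@@H](O)[C@H]2OC4)cc1` gives 4780 nM in this assay, a number within the scatter of that of compound 1, so the two cannot be ranked. Compound 2 `O=C1C=C(NC2CCCC2)C(=O)c2c1nc1n2[C@H]2OC[C@@H](O)[C@H]2OC1` reaches only the limit > 16000 nM in this assay. Going by the values given here, the step of an at least 3.3-fold lower number from compound 2 to compound 3 (0.52 log units; beyond the scatter) is the one comparison that bears on the unmeasured compound 4 `O=C1C(NC2CCCCC2)=CC(=O)c2c1nc1n2[C@H]2OC[C@@H](O)[C@H]2OC1`, which differs from compound 1 by cyclohexyl in place of 2-methoxyphenyl on an amine nitrogen. That measured step put an aryl group in place of a cycloalkyl group and lowered the number; the change to compound 4 runs the other way, so a rise of similar size is expected in this assay. One of the three values already sits at the limit of > 16000 nM in this assay, at which 1 of the 3 values shown sits, and compound 4 may likewise give only a limit. Compound 4 is therefore estimated at 20000 nM, with a range from 8000 nM to 50000 nM. The expected step of a 2.7-fold higher number from compound 1 to compound 4 (0.43 log units; beyond the scatter) lies beyond the scatter.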

Compound 4, half-maximal inhibitory concentration: > 16000 nM
Compound 4: no number, only a limit; the forecaster's own chance of this, stated with the estimate: 60%; the middle value lies beyond the limit too.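

Replacing the aryl group with a cycloalkyl group on this amine nitrogen in this assay gives an at least 2.1-fold higher number from compound 1 to compound 4 (0.33 log units; beyond the scatter). This runs in the opposite direction to an at least 3.3-fold lower number from compound 2 to compound 3 (0.52 log units; beyond the scatter), so the aryl-to-cycloalkyl difference now holds across two measured steps, both of which are open-ended. Among the compounds shown, both cycloalkyl compounds, compound 2 and compound 4, end in a limit rather than a number: the limit of > 16000 nM in this assay, at which 2 of the 4 values shown sit.

Cyclopentyl and cyclohexyl cannot be ranked against each other. The compounds shown also leave open whether a benzyl group or a longer alkyl chain on this nitrogen would behave like the aryl or the cycloalkyl groups.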